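The source may hold more compounds than are shown below. What is called first, only, known or untested is meant among the compounds shown, and "the series" means these compounds.

Measured so far:
compound 1, `COC(=O)C1=C(C)N=C(C)/C(=C(\O)OC)C1c1cc(Cl)cc(Cl)c1`: 93.3 nM
compound 2, `COC(=O)C1=C(C)N=C(C)/C(=C(/O)OC)C1c1cccc(Cl)c1`: 15.9 nM

Both numbers come from a functional assay (muscle tissue) with Cavia porcellus as the target; a lower number here means that less compound is needed, a higher number that more compound is needed for the effect. Of the two, compound 1 gives the higher number, 93.3 nM, while compound 2 gives 15.9 nM, and this gap lies beyond the scatter of repeated measurements of this kind. Among these two, compound 1 is therefore the one that needs more material to produce the effect.

The next compound, compound 3 `COC(=O)C1=C(C)N=C(C)/C(=C(\O)OC)C1c1cc(C)ccc1C`, has not yet been measured. It differs from compound 1 in one place: 2,5-dimethylphenyl in place of 3,5-dichlorophenyl on a saturated ring carbon. Among the compounds with values here, no pair of measured compounds shows this exact change, so there is no measured step to lean on. The two measured values only show that the group at this position can move the number by a good margin, as the difference between compound 1 and compound 2 does. For compound 3, a step from compound 1 that is modest, leaning toward a lower number, is expected a 1.9-fold lower number from compound 1 to compound 3 (0.27 log units; within the scatter). Compound 3 is accordingly estimated at 50 nM, with a range from 10 nM to 250 nM.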

Compound 3, half-maximal effective concentration: 100 nM
Estimate against measurement, compound 3: 2.0-fold (0.30 log units) below, and the stated range covers the measured number.
By their numbers in this assay, from the lowest: compound 2; then compounds 1 and 3 (each within the scatter of the next).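

In this assay the exchange of 3,5-dichlorophenyl for 2,5-dimethylphenyl on the saturated ring carbon gives a 1.1-fold higher number from compound 1 to compound 3 (0.03 log units; within the scatter) and so leaves the number unchanged within the scatter. Within the data shown here, the earlier pair showed only that compounds can lie well apart, whereas this single change shows that replacing both chlorine atoms with methyl groups and altering their places on the phenyl ring need not move the number, at least for this pair. Nothing measured here explains why the two numbers stay together, and no independent data on these groups are available to account for it.

Going by these compounds, the kind of substituent and its place on the ring change together in this step, so the separate contribution of each remains open. A phenyl ring carrying an amine or a carboxylic acid, or a longer alkyl chain in place of the ring, would test whether this position also accepts groups quite unlike the two compared here.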